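The compounds below may be only part of what the source reports. "The series", "measured", "known", "first", "only" and "open" are said of these compounds alone.

Measured compounds and their numbers in a functional assay on ileum for antagonist activity at histamine H1 receptor (Cavia porcellus); a lower number here means tighter binding, a higher number weaker binding:
compound 1, `N=C(NCCCc1c[nH]cn1)NCCCC(c1ccccc1)c1ccccn1`; in this assay compound 1 gives 251 nM
compound 2, `N=C(NCCCc1c[nH]cn1)NCCC(c1ccc(Cl)cc1)c1ccccn1`; compound 2 gives 77.6 nM
compound 3, `N=C(NCCCc1c[nH]cn1)NCCC(c1ccc(Br)cc1)c1ccccn1`; compound 3 gives 120 nM

Compound 3 stands second highest of these three numbers. Its nearest neighbour is compound 2, and the step of a 1.5-fold higher number from compound 2 to compound 3 (0.19 log units; within the scatter) lies within the scatter, so the two cannot be told apart with confidence. Compound 1 gives a higher number than compound 3, but the two differ in more than one place, so their values simply stand side by side without a single step between them.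

Compound 4, `N=C(NCCCc1c[nH]cn1)NCCC(c1ccc(F)c(F)c1)c1ccccn1`, arises from compound 3 by the change (3,4-difluorophenyl in place of 4-bromophenyl on a saturated chain carbon bound to an aromatic carbon and a saturated chain carbon). For the measured compounds named here, the one measured step that bears on this ring is the halogen swap a 1.5-fold higher number from compound 2 to compound 3 (0.19 log units; within the scatter), which stayed within the scatter. The new change again exchanges halogens on the same ring, so a step of similar small size is expected: no change at the digits printed from compound 3 to compound 4 (within the scatter), not beyond the scatter. Compound 4 is therefore estimated at 120 nM, with a range from 50 nM to 300 nM.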

Compound 4, dissociation constant: 85.1 nM
The estimate for compound 4 lay 1.4-fold (0.15 log units) above the measured number; measured number inside the range.
By their numbers in this assay, from the lowest: compounds 2, 4 and 3 (each within the scatter of the next); then compound 1.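

Earlier, only one halogen had been exchanged for another on this ring, and that exchange stayed within the scatter. Here, the 3,4-difluorophenyl group carries two fluorines rather than one heavier halogen, yet in this assay it still cannot be told apart from 4-bromophenyl (a 1.4-fold lower number from compound 3 to compound 4 (0.15 log units; within the scatter)) or from 4-chlorophenyl (a 1.1-fold higher number from compound 2 to compound 4 (0.04 log units; within the scatter)), so at this place on the chain, all three halogen-bearing rings read alike. Nothing measured here accounts for this likeness.

The compounds shown leave open whether the same holds for a ring without halogen, such as a plain phenyl group on this same chain, or for a ring bearing a methoxy group or an amine. They also leave open whether a larger group than these halogens would separate clearly from compounds 2, 3 and 4.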